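Chain Extension on a Benzyl Triazole Aromatase Inhibitor

The compounds below may be only part of what the source reports. "The series", "measured", "known", "first", "only" and "open" are said of these compounds alone.

Compound 3 `CCCc1cn(Cc2ccccc2)nn1` is one of three compounds examined in an assay on isolated protein for inhibition of Aromatase (Homo sapiens), read by fluorescence and colorimetric assay, with a stated time of 30 min (on this read-out higher numbers stand for weaker inhibition and lower numbers for stronger inhibition), where compound 3 gives 12600 nM. Compound 1 `CCCc1cn(C(c2ccccc2)c2ccccc2)nn1` gives 11000 nM, and the step of a 1.1-fold higher number from compound 1 to compound 3 (0.06 log units; within the scatter) shows that the phenyl on the chain carbon bound to the core makes no difference that can be trusted. Compound 2 `CCCCCCCc1cn(Cc2ccc(C#N)cc2)nn1`, which carries a heptyl chain and a nitrile on the benzyl ring, gives 3070 nM; compound 3 therefore stands at the highest number of the three, close to compound 1 and well apart from compound 2.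

Compound 4 `CCCCCCCc1cn(Cc2ccccc2)nn1` differs from compound 3 by butyl in place of hydrogen on a saturated chain carbon, three bonds along the chain from an aromatic carbon. Going by the values given here, no measured step isolates this change: compound 2 shares the longer chain with compound 4 but also carries the nitrile, so its lower number cannot be assigned to the chain alone. The gap between compound 3 and compound 2 nonetheless suggests that the longer chain may account for part of it. The author therefore expects a moderate step of a 2.1-fold lower number from compound 3 to compound 4 (0.32 log units; beyond the scatter) toward a lower number for compound 4, estimated at 6000 nM, within a range from 2500 nM to 15000 nM.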

Compound 4, half-maximal inhibitory concentration: 9530 nM
Compound 4: the middle estimate sits 1.6-fold (0.20 log units) below what was measured; the measured number falls inside the stated range.
By their numbers in this assay, from the lowest: compound 2; then compounds 4, 1 and 3 (each within the scatter of the next).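

In this assay, the step of a 1.3-fold lower number from compound 3 to compound 4 (0.12 log units; within the scatter) shows that butyl in place of hydrogen on this saturated chain carbon, three bonds along the chain from an aromatic carbon, gives no difference that can be trusted. Going by these compounds alone, the step of a 3.1-fold higher number from compound 2 to compound 4 (0.49 log units; beyond the scatter), hydrogen in place of cyano on an aromatic carbon, is the first to isolate the nitrile, and it lies beyond the scatter, so the chain extension and the nitrile now read separately. Nothing at hand explains either step.

The compounds shown leave open whether the nitrile step would hold on the shorter chain of compound 3. They also leave open how a longer chain, a terminal amine or a carboxylic acid at this position, or fluorine in place of cyano, would read.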